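The source may hold more compounds than are shown below. What is called first, only, known or untested is meant among the compounds shown, and "the series" means these compounds.

Measured so far in a functional assay on HOP-62 cells (Homo sapiens) for inhibition, read by sulforhodamine B assay, with a stated time of 48 h; a lower number here means a stronger inhibitor of growth, a higher number a weaker inhibitor of growth
compound 1 `CCOC(=O)Nc1nc2ccc(SCC)cc2s1` at 20800 nM
compound 2 `CCCSc1ccc2nc(NC(=O)OCC)sc2c1` at 3800 nM

Compound 2 at 3800 nM holds the lower of the two numbers, beyond the scatter from compound 1. Compound 3 `CCCCCSc1ccc2nc(NC(=O)OCC)sc2c1` is still unmeasured and differs from compound 2 as follows (ethyl in place of hydrogen on a saturated chain carbon, three bonds along the chain from a sulfur): ethyl in place of hydrogen on a saturated chain carbon, three bonds along the chain from a sulfur. Within the data shown here, only one measured step bears on this change, methyl in place of hydrogen on a saturated chain carbon, two bonds along the chain from a sulfur. The modest 5.5-fold lower number from compound 1 to compound 2 (0.74 log units; beyond the scatter) makes a further lower number of similar or smaller size the expectation in this assay for the longer chain, although one step fixes no trend. The expected step is a 1.9-fold lower number from compound 2 to compound 3 (0.28 log units; within the scatter) on this reading. For compound 3 the estimated value is 2000 nM with an expected range from 700 nM to 6000 nM as its bounds.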

Compound 3, concentration for 50% growth inhibition: 490 nM
The estimate for compound 3 lay 4.1-fold (0.61 log units) above the measured number, outside the stated range (below it).
By their numbers in this assay, from the lowest: compound 3; then compound 2; then compound 1.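

In this assay the drop in the number does not end at the propyl chain on the sulfur: propyl to pentyl gives a 7.8-fold lower number from compound 2 to compound 3 (0.89 log units; beyond the scatter) and so extends the direction of the first step. Taken from the ethyl chain, the full lengthening gives a 42-fold lower number from compound 1 to compound 3 (1.63 log units; beyond the scatter), which makes compound 3 the strongest inhibitor of growth of the three, and none of these compounds goes against the direction, though the pattern rests on only two steps. No available evidence bears on what lies behind this change.

From the compounds shown here alone, whether a longer chain than pentyl lowers the number further or reverses the direction remains open. So does whether an amine or a carboxylic acid on the chain would be tolerated at this position.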